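Chloroethenyl for Iodoacetamidomethyl on a Shared Nucleoside Core

The compounds below may be only part of what the source reports. "The series", "measured", "known", "first", "only" and "open" are said of these compounds alone.

Measured compounds:
- compound 1, `O=C(CI)NCc1cn([C@H]2C[C@H](O)[C@@H](CO)O2)c(=O)[nH]c1=O`: 107000 nM
- compound 2, `CC(C)Nc1ncnc2c1ncn2C1C[C@@H](CO)[C@@H](CO)C1`: > 200000 nM
- compound 3, `CC1(C)[C@@H](CCCO)C[C@H]1n1nnc2c(Cl)nc(N)nc21`: > 200000 nM

Among the compounds with values here, in an ADME assay on L1210/0 cells (Mus musculus) for cytotoxicity, with a stated time of 48 h (on this read-out lower numbers stand for stronger inhibition and higher numbers for weaker inhibition), compound 1 gives 107000 nM, the only definite number among the three. For compound 2 the assay records only a limit, > 200000 nM. For compound 3 likewise only a limit is recorded, > 200000 nM. Within the data shown here, compound 1 therefore stands as the sole compound with a measured half-maximal inhibitory concentration, while the limit of > 200000 nM in this assay, at which 2 of the 3 values shown sit, holds the other two.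

The step to compound 4, `O=c1[nH]c(=O)n([C@H]2C[C@H](O)[C@@H](CO)O2)cc1/C=C/Cl`, changes compound 1 at one place: 2-chloroethenyl in place of (((iodomethyl)carbonyl)amino)methyl on an aromatic carbon. Nothing measured speaks to a change of this kind, and the core is kept. Among the measured compounds shown here, with no comparable step available, the expectation is for a small step, within or close to the usual scatter, from compound 1 to compound 4 in this assay, estimated as a 1.4-fold higher number from compound 1 to compound 4 (0.15 log units; within the scatter). Compound 4 is accordingly estimated at 150000 nM, expected to fall between 30000 nM and 600000 nM, with a real chance that only a limit is reported.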

Compound 4, half-maximal inhibitory concentration: > 200000 nM
Compound 4: no number, only a limit; the forecaster's own chance of this, stated with the estimate: 35%; at least 1.3-fold (0.12 log units) between middle value and limit.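

In this assay, within the data shown here, the exchange of (((iodomethyl)carbonyl)amino)methyl for 2-chloroethenyl on this aromatic carbon provides the only readable step at this position, and it shows an at least 1.8-fold higher number from compound 1 to compound 4 (0.27 log units; that floor lies within the scatter). Compound 4 gives > 200000 nM, which is a limit and not a number. Among these compounds, the step is therefore only a floor, it does not set the two compounds apart beyond the scatter, and compound 1 remains the only compound with a definite number: the limit of > 200000 nM in this assay, at which 3 of the 4 values shown sit.

The step replaces the whole group at once, leaving open whether the iodomethyl end or the amide goes with the definite number of compound 1. Also open, from the compounds shown here alone, is how an aminomethyl group, a chloroacetamidomethyl group or a longer chain on this aromatic carbon would read in this assay.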